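Swapping a saturated ring for an aromatic one at the amide side chain

The compounds below may be only part of what the source reports. "The series", "measured", "known", "first", "only" and "open" are said of these compounds alone.

Two compounds share a common core and differ only in the group on a saturated chain carbon bound to a carbonyl carbon. In a functional assay on Venous blood for antagonist activity at C-X-C chemokine receptor type 3 (Homo sapiens), read by flow cytometry, with a stated time of 30 min, in the presence of a further agent that is not named here (a lower number here means a stronger inhibitor, a higher number a weaker inhibitor), compound 1 `C[C@@H]1CN(c2sc(C(F)(F)F)nc2-c2nc3ccccc3[nH]2)CCN1C(=O)CN1C(=O)OC[C@@H]1c1ccccc1` gives 1380 nM, while compound 2 `C[C@@H]1CN(c2sc(C(F)(F)F)nc2-c2nc3ccccc3[nH]2)CCN1C(=O)Cn1cnc2c1CCN(C)C2` gives 135 nM, the lowest of the two numbers shown; the step of a 10-fold lower number from compound 1 to compound 2 (1.01 log units; beyond the scatter) was large. Compound 3 `C[C@@H]1CN(c2sc(C(F)(F)F)nc2-c2nc3ccccc3[nH]2)CCN1C(=O)Cn1cnc2cccnc21` carries a group of 9 heavy atoms (6 carbon, 3 nitrogen; one five-membered aromatic ring with 2 hetero atoms, one six-membered aromatic ring with 1 hetero atom) in place of a group of 10 heavy atoms (7 carbon, 3 nitrogen; one five-membered aromatic ring with 2 hetero atoms, one six-membered non-aromatic ring with 1 hetero atom), on a saturated chain carbon bound to a carbonyl carbon. For the measured compounds named here, no measured step covers this exchange, so the expected step of a 3.0-fold higher number from compound 2 to compound 3 (0.47 log units; beyond the scatter) is uncertain and could fall either side of the scatter. Compound 3 is therefore estimated at 400 nM, within 80 nM to 2000 nM.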

Compound 3, half-maximal inhibitory concentration in the C-X-C chemokine receptor type 3 assay: 70 nM
Estimate against measurement, compound 3: 5.7-fold (0.76 log units) above; the measured number lies below the stated range.
By their numbers in the C-X-C chemokine receptor type 3 assay, from the lowest: compounds 3 and 2 (each within the scatter of the next); then compound 1.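

In the C-X-C chemokine receptor type 3 assay, a six-membered aromatic ring with 1 hetero atom serves this position as well as the six-membered non-aromatic ring with 1 hetero atom (a 1.9-fold lower number from compound 2 to compound 3 (0.29 log units; within the scatter)), and it keeps the large gain over the group in compound 1 (a 20-fold lower number from compound 1 to compound 3 (1.29 log units; beyond the scatter)). In a physicochemical assay for solubility, in simulated intestinal fluid (a lower number here means a less soluble compound, a higher number a more soluble compound), the same exchange does show a difference (an at least 4.2-fold lower number from compound 2 to compound 3 (0.63 log units; beyond the scatter)). In the physicochemical assay, compound 3 gives 214 ug/mL. That step starts from compound 2, whose value in the physicochemical assay is a limit of the assay (> 920 ug/mL): the limit of > 920 ug/mL in the physicochemical assay, at which 1 of the 2 values shown sits.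

The compounds shown leave open whether an amine or a carboxylic acid on the six-membered aromatic ring would hold the number in the C-X-C chemokine receptor type 3 assay while moving the number in the physicochemical assay.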